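Swapping fluoro for methoxy on a urea-linked ring

The compounds below may be only part of what the source reports. "The series", "measured", "known", "first", "only" and "open" are said of these compounds alone.

Compound 1 `O=C(Nc1cccc(F)c1)N[C@H]1CC[C@H](Oc2ccc(F)cc2)CC1` is a urea joining a fluorophenyl group to a cyclohexane that carries a second fluorophenyl ether. In a functional assay on CRL2813 cells (Homo sapiens) for cytotoxicity, read by sulforhodamine B assay, with a stated time of 5 days (a lower number here means a stronger inhibitor, a higher number a weaker inhibitor), compound 1 gives 8300 nM. Among the compounds with a numerical result this is the highest number, so the weakest inhibition of cell growth. Compound 3 `O=C(Nc1cccc(C(F)(F)F)c1)N[C@H]1CC[C@H](Oc2ccc(C(F)(F)F)cc2)CC1`, which carries trifluoromethyl on both aromatic rings, gives 460 nM, a lower number that lies beyond the usual scatter. Compound 2 `O=C(Nc1ccccc1C(=O)O)N[C@H]1CC[C@@H](Oc2ccc(F)cc2)CC1`, with a carboxylic acid on the ring attached to the urea, gives > 20000 nM, and this is a limit of the assay rather than a number (the limit of > 20000 nM in this assay, at which 1 of the 3 values shown sits).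

Compound 4 `COc1cccc(NC(=O)N[C@H]2CC[C@H](Oc3ccc(F)cc3)CC2)c1` has not yet been measured in this assay . It differs from compound 1 in one place: methoxy in place of fluoro on an aromatic carbon. Among the compounds with values here, no measured pair of compounds shows this same exchange, so there is nothing to lean on except the general picture that small changes on this ring have so far moved the numbers only modestly. The step from compound 1 to compound 4 is expected to stay within the scatter, a 1.0-fold lower number from compound 1 to compound 4 (0.02 log units; within the scatter). Compound 4 is therefore estimated to give about 8000 nM, with a likely range from 3000 nM to 20000 nM.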

Compound 4, half-maximal inhibitory concentration: 14000 nM
Beside the measured number, compound 4's estimate is 1.8-fold (0.24 log units) below it; the range from low to high includes it.
By their numbers in this assay, from the lowest: compound 3; then compounds 1 and 4 (each within the scatter of the next). At a limit, above all of these: compound 2.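

In this assay, the change from 3-fluorophenyl to 3-methoxyphenyl provides the first comparison among these compounds in which only one place differs, and it gives a 1.7-fold higher number from compound 1 to compound 4 (0.23 log units; within the scatter). At this aromatic carbon, meta to a large group, the assay therefore does not tell fluoro and methoxy apart, although methoxy is the larger of the two by heavy atoms and adds a hydrogen-bond acceptor that fluoro, as counted here, does not. With only this single exchange to go on, and no measurement that bears on it, the compounds shown offer no explanation for this outcome.

Going by these compounds, it remains open whether an amine, a nitrile or a longer chain such as ethoxy at this same position would also leave the number within the scatter of compound 1, or would move it clearly in either direction. The same exchange on the other aromatic ring, the one attached through the ether oxygen, where fluoro stands in both compound 1 and compound 4, is also left open.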